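The source may report more compounds than this note shows. Statements on the series, on what has been measured and on what is new or still open speak of the compounds shown alone.

Compound 1 `O=c1n(Cc2cn3ccc(Cl)cc3n2)c2cnccc2n1C1CC1`: 22300 nM
Compound 2 `N#Cc1c(Cn2c(=O)n(C3CC3)c3ccncc32)nc2cc(Cl)ccn12`: 22500 nM

In an ADME assay on HEp-2 cells (Homo sapiens) for cytotoxicity, read by CCK-8 assay, with a stated time of 6 days (on this read-out higher numbers stand for lower toxicity in this test and lower numbers for higher toxicity in this test), compound 1 gives 22300 nM and compound 2 gives 22500 nM. These two numbers lie within the scatter of each other, so on the evidence so far compound 1 cannot be told apart from compound 2 in this assay.

Compound 3 `CCCCNc1c(Cn2c(=O)n(C3CC3)c3ccncc32)nc2cc(Cl)ccn12` is not yet measured. It differs from compound 1 by butylamino in place of hydrogen on an aromatic carbon. For the measured compounds named here, the only measured step that bears on this change is the one from compound 1 to compound 2, where a cyano in place of hydrogen on an aromatic carbon gave a 1.0-fold higher number from compound 1 to compound 2 (0.00 log units; within the scatter). That step shows this position tolerating a substituent without any shift beyond the scatter. A butylamino group is a different kind of substituent, so the precedent is indirect, and no step beyond the scatter is expected in this assay.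

Compound 3 is therefore estimated at 20000 nM, with a range from 8000 nM to 50000 nM; this estimate means a 1.1-fold lower number from compound 1 to compound 3 (0.05 log units; within the scatter).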

Compound 3, half-maximal cytotoxic concentration: > 100000 nM
Compound 3: no number, only a limit (the forecaster's own chance of this, stated with the estimate: 20%); middle value at least 5.0-fold (0.69 log units) away from the limit.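

In this assay compound 3 gives > 100000 nM, which is a limit of the assay and not a number: the limit of > 100000 nM in this assay, at which 1 of the 3 values shown sits. This position on the five-membered aromatic ring does not respond to every substituent alike: cyano left the number within the scatter, whereas butylamino gives an at least 4.4-fold higher number from compound 1 to compound 3 (0.65 log units; beyond the scatter), a shift towards lower toxicity in this test. Swapping one substituent directly for the other gives an at least 4.4-fold higher number from compound 2 to compound 3 (0.64 log units; beyond the scatter), so the shift follows the identity of the group and not merely the presence of a substituent at this position.

The limit leaves the full size of both steps unknown. Also open, going by these compounds, is whether the shift depends on the linking nitrogen or on the chain, which a plain amine, a shorter ethylamino chain or an all-carbon butyl chain could separate.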